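The source may report more compounds than this note shows. Statements on the series, on what has been measured and on what is new or still open speak of the compounds shown alone.

Of the compounds shown here, three built on one shared core have been measured in an in vitro functional assay on cells for agonist activity at Bombesin receptor subtype-3 (Mus musculus), read by luminescence and calcium flux; on this read-out higher numbers stand for an effect only at larger amounts of compound and lower numbers for an effect already at smaller amounts. Compound 1 `CCC(C)(CC)Cc1cnc(CCc2ccc(-c3ccccc3C(=O)O)cc2)[nH]1` gives 30 nM. Compound 2 `N#Cc1ccccc1Cc1cnc(CCc2ccc(-c3ccccc3C(=O)O)cc2)[nH]1` gives 642 nM, and compound 3 `COc1ccccc1Cc1cnc(CCc2ccc(-c3ccccc3C(=O)O)cc2)[nH]1` gives 163 nM. Compound 3 thus stands second highest of the three numbers: its nearest neighbour is compound 2, while compound 1 lies furthest away. The unmeasured compound 4 `O=C(O)c1ccccc1-c1ccc(CCc2ncc(CC3CCCCCC3)[nH]2)cc1` differs from compound 3 in one place: cycloheptyl in place of 2-methoxyphenyl on a saturated chain carbon bound to an aromatic carbon.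

Going by the values given here, two measured steps bear on this change. When the 1-ethyl-1-methylpropyl group of compound 1 was exchanged for an aromatic group, the number rose, by a 5.4-fold higher number from compound 1 to compound 3 (0.74 log units; beyond the scatter) and by a 21-fold higher number from compound 1 to compound 2 (1.33 log units; beyond the scatter). Exchanging one substituent on that aromatic ring for another moved the number less, by a 3.9-fold lower number from compound 2 to compound 3 (0.60 log units; beyond the scatter). The step to compound 4 runs the other way: the aromatic ring leaves and a seven-membered non-aromatic ring of carbon only enters, so the side group becomes closer in kind to that of compound 1 than to those of compounds 2 and 3. A lower number in this assay is therefore expected, of a size roughly undoing the earlier rise, which amounts to an estimated 4.1-fold lower number from compound 3 to compound 4 (0.61 log units; beyond the scatter). Compound 4 is estimated at 40 nM, with a range from 15 nM to 120 nM.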

Compound 4, half-maximal effective concentration: 5.7 nM
For compound 4 the middle estimate is 7.0-fold (0.85 log units) above the measured one; the whole stated range lies above it.
By their numbers in this assay, from the lowest: compound 4; then compound 1; then compound 3; then compound 2.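

At this position, on a saturated chain carbon bound to an aromatic carbon, replacing an aromatic ring with cycloheptyl gives a 29-fold lower number from compound 3 to compound 4 (1.46 log units; beyond the scatter) and a 110-fold lower number from compound 2 to compound 4 (2.05 log units; beyond the scatter) in this assay. The step away from the open-chain group is also beyond the scatter, at a 5.3-fold lower number from compound 1 to compound 4 (0.72 log units; beyond the scatter), so the non-aromatic groups do not behave alike and compound 1 does not mark the lowest number reachable here. Compound 4 now has the lowest number of the four, which shows that an all-carbon ring with no aromatic character and no hydrogen-bond acceptor fits the trend from the aromatic groups to compound 1 but goes well beyond it, and nothing measured alongside these values explains that difference.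

The compounds shown leave open whether the seven-membered ring size itself matters, since a cyclopentyl or cyclohexyl group at the same place would separate ring size from the mere presence of a saturated ring. As far as these compounds go, it also remains open how a ring carrying an amine, as in a piperidine, would read, or how a plain phenyl group without the methoxy or cyano substituent would compare.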